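The compounds below may be only part of what the source reports. "The series", "measured", "known", "first", "only" and "open" are said of these compounds alone.

In a functional assay on HEK293 cells for agonist activity at growth hormone secretagogue receptor type 1 (Homo sapiens), read by HTRF and inositol phosphate accumulation, with a stated time of 90 min, in the presence of a further agent that is not named here (on this read-out lower numbers stand for smaller maximal responses and higher numbers for larger maximal responses), three compounds have been measured:

compound 1 `Cc1ccc2[nH]c(C(=O)N[C@H]3CCN(S(=O)(=O)c4ccccc4)C[C@@H]3C(=O)NCCN(C)C)cc2c1` gives 98%
compound 2 `Cc1ccc2[nH]c(C(=O)N[C@H]3CCN(S(=O)(=O)c4cccnc4)C[C@@H]3C(=O)NCCN(C)C)cc2c1` gives 93%
compound 3 `Cc1ccc2[nH]c(C(=O)N[C@H]3CCN(S(=O)(=O)N4CCCCC4)C[C@@H]3C(=O)NCCN(C)C)cc2c1` gives 105%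

Compound 3 is within the scatter of compound 1, as a number 7 percentage points higher from compound 1 to compound 3 (within the scatter) shows, and stands apart only from compound 2, through a number 12 percentage points higher from compound 2 to compound 3 (beyond the scatter). Compound 4 `Cc1ccc2[nH]c(C(=O)N[C@H]3CCN(S(=O)(=O)N(C)C)C[C@@H]3C(=O)NCCN(C)C)cc2c1` differs from compound 3 in one place: dimethylamino in place of piperidin-1-yl on a sulfonyl sulfur. Both earlier steps at this sulfonyl sulfur bear on the change, one within the scatter and one modest, and every group tried there so far has given a large maximal response. No step beyond the scatter is therefore expected here, and the step from compound 3 to compound 4 is estimated as a number 5 percentage points lower from compound 3 to compound 4 (within the scatter). Compound 4 is expected to give 100%, within a range from 88% to 112%.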

Compound 4, largest response reached (Emax), in percent of the reference or control that the assay uses: 100%
For compound 4 middle estimate and measured number coincide at the digits printed; the measured number falls inside the stated range.
By their numbers in this assay, from the lowest: compounds 2, 1, 4 and 3 (each within the scatter of the next, the first and the last beyond it).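

Removing the ring at the sulfonyl sulfur changes nothing that can be told apart: dimethylamino in place of piperidin-1-yl gives a small step (a number 5 percentage points lower from compound 3 to compound 4 (within the scatter)). The same group also stays level with phenyl (a number 2 percentage points higher from compound 1 to compound 4 (within the scatter)) and with pyridin-3-yl (a number 7 percentage points higher from compound 2 to compound 4 (within the scatter)), so in these compounds a large maximal response at this position needs no ring. No independent measurement explains this result.

As far as these compounds go, whether morpholin-4-yl or a smaller methylamino group on this sulfur would hold the response stays open. Equally open, from the compounds shown here alone, is what a carboxylic acid on the phenyl group would do.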